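Swapping fluoro for methyl in a weakly cytotoxic pair

The source may hold more compounds than are shown below. What is called first, only, known or untested is meant among the compounds shown, and "the series" means these compounds.

In a functional assay on BT-549 cells (Homo sapiens) for cytotoxicity, read by MTT assay, with a stated time of 24 h (on this read-out lower numbers stand for stronger inhibition and higher numbers for weaker inhibition), compound 1 `O=C1c2ccccc2OCC1Cc1ccc(F)cc1` reaches only a limit, > 200000 nM. This figure is a limit of the assay and not a number, so compound 1 has no exact place on the scale. Compound 2 `COc1ccc(CC2COc3ccccc3C2=O)c(OC)c1` shares the core and gives a real reading in this assay, 61900 nM. Compound 3 `Cc1ccc(CC2COc3ccccc3C2=O)cc1` has not been measured yet. It differs from compound 1 at one spot: methyl in place of fluoro on an aromatic carbon. This is methyl in place of fluoro on an aromatic carbon, para to a large group. Within the data shown here, the one exact reading here, 61900 nM for compound 2, is still a weak result, so only a small gain is expected. A modest move toward stronger inhibition is expected, an at least 1.5-fold lower number from compound 1 to compound 3 (0.18 log units; that floor lies within the scatter), and a result that again stops at the limit would be no surprise. For compound 3 the estimated value is 130000 nM, with an expected range of 50000 nM to 250000 nM.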

Compound 3, half-maximal inhibitory concentration: 42200 nM
Compound 3: the middle estimate sits 3.1-fold (0.49 log units) above what was measured; the measured number lies below the stated range.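

Among these compounds, this is the first exact reading for a compound that differs from compound 1 at a single spot, and it shows that the reading responds to a swap of one heavy atom on an aromatic carbon para to a large group. In this assay, methyl in place of fluoro gives an at least 4.7-fold lower number from compound 1 to compound 3 (0.67 log units; beyond the scatter), a change beyond the usual scatter, although compound 3 remains a weak compound on this scale. The true size of the step stays unknown, and only its lower bound can be given, because compound 1 stands at a limit: the limit of > 200000 nM in this assay, at which 1 of the 3 values shown sits.

The compounds shown leave open whether the gain belongs to methyl itself or would also appear with an amine, a carboxylic acid or a longer chain at this spot. They also leave open whether the same swap would act alike on a different core or in other cells.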